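The compounds below may be only part of what the source reports. "The series", "measured", "known", "first", "only" and "open" are said of these compounds alone.

In a functional assay on DU-145 cells (Homo sapiens) for cytotoxicity, read by XTT assay, with a stated time of 24 h (a higher number here means a weaker inhibitor, a lower number a stronger inhibitor), compound 1 `Cc1cc(Cl)c2c(c1O)C(=O)C=CC2=O` gives 9300 nM, while compound 2 `COc1c(C)cc(Cl)c2c1C(=O)C=CC2=O` gives 36500 nM, the higher of the two numbers and so the weaker result. Compound 3 `CC(=O)Oc1c(C)cc(Cl)c2c1C(=O)C=CC2=O` keeps the core of compound 2 with one change: acetyl in place of methyl on an oxygen on an aromatic ring. Among the measured compounds shown here, only one measured step touches that same oxygen, where methyl replaces hydrogen, and it is modest: a 3.9-fold higher number from compound 1 to compound 2 (0.59 log units; beyond the scatter). For the measured compounds named here, no measurement yet shows what acetyl does there, so a modest move towards a lower number is expected, with little certainty: a 2.0-fold lower number from compound 2 to compound 3 (0.31 log units; beyond the scatter). For compound 3 the estimated value is 18000 nM, with an expected range of 6000 nM to 45000 nM.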

Compound 3, half-maximal inhibitory concentration: 12500 nM
Compound 3: middle estimate off by 1.4-fold (0.16 log units), on the high side; low and high end bracket the measured number.
By their numbers in this assay, from the lowest: compounds 1 and 3 (each within the scatter of the next); then compound 2.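

On this oxygen, the step in this assay shows that the outcome depends on which group is attached: a 2.9-fold lower number from compound 2 to compound 3 (0.47 log units; beyond the scatter), so swapping methyl for acetyl recovers much of what the first capping step lost. Measured against the free hydroxyl, the acetyl compound shows a 1.3-fold higher number from compound 1 to compound 3 (0.13 log units; within the scatter), which means that putting a group on this oxygen does not always raise the number. Nothing available explains the difference between methyl and acetyl here. On these data alone, whether a longer chain on this oxygen, or a benzoyl group, would fall nearer compound 2 or compound 3 remains open.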